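The source may report more compounds than this note shows. Statements on the series, on what has been measured and on what is new or still open speak of the compounds shown alone.

Of the compounds shown here, two from this series have been tested in a functional assay on MDA-MB-468 cells (Homo sapiens) for cytotoxicity, read by sulforhodamine B assay, with a stated time of 48 h, tested at 100 uM; a higher number here means a weaker effect of the compound at the concentration tested, a lower number a stronger effect. Compound 1, `COc1cc(-c2cc(/C=C/C(=O)c3ccc(Cl)c(Cl)c3)[nH]n2)cc(OC)c1OC`, gives -37% in this assay. Compound 2, `COc1ccc(-c2cc(/C=C/C(=O)c3ccc(N)cc3)[nH]n2)cc1OC`, gives -73% in this assay. Of the two numbers, that of compound 1 is the higher, and the gap to compound 2 lies beyond the usual scatter of repeated measurements, so compound 1 shows the weaker effect of the two at the concentration tested. The two compounds differ in more than one place, so no single structural step can be read from their values.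

Compound 3, `COc1cc(-c2cc(/C=C/C(=O)c3ccc(F)c(F)c3)[nH]n2)cc(OC)c1OC`, has not yet been measured in this assay. It differs from compound 1 in one place: 3,4-difluorophenyl in place of 3,4-dichlorophenyl on a carbonyl carbon. For the measured compounds named here, with no measured pair of this kind to lean on, only a modest shift is expected, if any, and the direction is open; a slightly higher number than that of compound 1 seems somewhat more likely than a lower one. Compound 3 is therefore expected to give about -25% in this assay, within a range from -60% to 10%, which would amount to an expected step of a number 12 percentage points higher from compound 1 to compound 3 (beyond the scatter).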

Compound 3, a percentage reported as activity, at one concentration (the size of the read-out at that concentration, not a potency): -26%
For compound 3 the middle estimate is 1 percentage points above the measured one, and the stated range covers the measured number.
By their numbers in this assay, from the lowest: compound 2; then compound 1; then compound 3.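

For the compounds shown here, replacing 3,4-dichlorophenyl with 3,4-difluorophenyl on a carbonyl carbon provides the first single-place comparison, and in this assay it gives a number 11 percentage points higher from compound 1 to compound 3 (beyond the scatter). This shows that the read-out responds to which of these two halogen pairs the phenyl ring carries, although the exchange keeps the ring and its place on the carbonyl carbon the same, and compound 3 still reads -26%. Nothing measured here offers an explanation for this step.

The compounds shown leave open how a plain phenyl, or a phenyl carrying a nitrile or a trifluoromethyl group, would read on this carbonyl carbon, and so whether the two halogenated groups mark a wider trend or only a single pair. They also leave open whether the same exchange would give a step of similar size on the core of compound 2, since that compound differs from compound 1 in more than one place and offers no direct comparison.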